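The source may report more compounds than this note shows. Statements on the series, on what has been measured and on what is new or still open speak of the compounds shown alone.

Compound 1 `CC(C)=CCC1Cc2c(OCCCNC(=O)c3cccs3)cc(=O)n(CCCO)c2CC1(C)C` is the starting point of this small set; in a functional assay on PANC-1 cells (Homo sapiens) for inhibition, read by MTT assay, with a stated time of 24 h, tested at 10 uM (on this read-out higher numbers stand for more inhibition at the one concentration tested (going by the name of the read-out) and lower numbers for less inhibition), compound 1 gives 5.6%. Compound 2 `CC(C)=CCC1Cc2c(OCCCNC(=O)c3ccc([N+](=O)[O-])cc3)cc(=O)n(CCCO)c2CC1(C)C` carries the change (4-nitrophenyl in place of thiophen-2-yl on a carbonyl carbon); in this assay compound 2 gives 9.1%, and the step is a number 3.5 percentage points higher from compound 1 to compound 2 (within the scatter). Compound 3 `CC(C)=CCC/C(C)=C/CC1Cc2c(OCCCNC(=O)c3cccs3)cc(=O)n(CCCO)c2CC1(C)C` has a different core, the two cores differing by 3-methylbut-2-en-1-yl in place of hydrogen on a saturated chain carbon bound to a double-bonded chain carbon; in this assay compound 3 gives 11.5%, a step of a number 5.9 percentage points higher from compound 1 to compound 3 (within the scatter). Compound 4 `CC(C)=CCC/C(C)=C/CC1Cc2c(OCCCNC(=O)c3ccc([N+](=O)[O-])cc3)cc(=O)n(CCCO)c2CC1(C)C` has not yet been measured. It differs from compound 3 by 4-nitrophenyl in place of thiophen-2-yl on a carbonyl carbon, the same change as that from compound 1 to compound 2, at the same place, a carbonyl carbon whose other neighbour is an amide-type nitrogen. Because a number 3.5 percentage points higher from compound 1 to compound 2 (within the scatter) stayed within the scatter, the step expected for compound 4 is similarly small, a number 3.5 percentage points higher from compound 3 to compound 4 (within the scatter). Compound 4 is therefore estimated at 15%, within 5% to 25%.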

Compound 4, a percentage reported as inhibition, at one concentration (the size of the read-out at that concentration, not a potency): 6.5%
For compound 4 the middle estimate is 8.5 percentage points above the measured one; low and high end bracket the measured number.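

In this assay, the exchange of thiophen-2-yl for 4-nitrophenyl on the larger core gives a number 5 percentage points lower from compound 3 to compound 4 (within the scatter), and beside the earlier step it shows no difference that can be told from scatter: the same change on two cores in this assay, a number 3.5 percentage points higher (within the scatter) from compound 1 to compound 2 and a number 5 percentage points lower (within the scatter) from compound 3 to compound 4, 8.5 percentage points apart, within the scatter of two such steps. The added 3-methylbut-2-en-1-yl gives a number 2.6 percentage points lower from compound 2 to compound 4 (within the scatter), and this agrees in the same way with its earlier step: the same change on two cores in this assay, a number 5.9 percentage points higher (within the scatter) from compound 1 to compound 3 and a number 2.6 percentage points lower (within the scatter) from compound 2 to compound 4, 8.5 percentage points apart, within the scatter of two such steps. Both changes are thus consistent with carrying over between the two cores, but with every step within the scatter, this does not show that either change has a real effect or that the effects add.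

The compounds shown leave open whether a different group on the carbonyl carbon, such as a phenyl bearing a carboxylic acid or an amine, would give a step beyond the scatter. They also leave open how any of these compounds would behave at other concentrations.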